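This account rests on a few compounds, and the source may have more. Where it says the series, first, only, none or still open, it means among the compounds named here.

Measured compounds:
compound 1 `O=C(NCCO)c1cccc2[nH]c(-c3ccccn3)nc12` — 568 uM
compound 2 `O=C(Nc1ccccc1F)c1cccc2[nH]c(-c3ccco3)nc12` — 25 uM
compound 3 `COc1ccc(-c2nc3c(C(=O)NCCCO)cccc3[nH]2)cc1OC` — 46 uM

In an ADME assay on Vero cells (Chlorocebus sabaeus) for cytotoxicity (on this read-out lower numbers stand for higher toxicity in this test and higher numbers for lower toxicity in this test), compound 3 gives 46 uM, the second highest of the three numbers. Its nearest neighbour is compound 2, which gives 25 uM, a gap within the scatter of this assay, so no order between the two can be read. The furthest is compound 1, which gives 568 uM, a higher number beyond the scatter.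

Compound 4 `COc1ccc(-c2nc3c(C(=O)Nc4ncccc4O)cccc3[nH]2)cc1OC` is not yet measured in this assay. It differs from compound 3 in one place: 3-hydroxypyridin-2-yl in place of 3-hydroxypropyl on an amide-type nitrogen. For the measured compounds named here, no step between measured compounds isolates this kind of change, so the expectation rests on the spread of the three numbers. Compound 2 also carries a ring on its amide nitrogen and gives a number within the scatter of compound 3; compound 1, with a chain on that nitrogen, sits higher. A small downward move or none beyond the scatter is the expected outcome for compound 4, the step from compound 3 to compound 4 being estimated as a 1.5-fold lower number from compound 3 to compound 4 (0.19 log units; within the scatter). Compound 4 is accordingly expected to give 30 uM, with a range of 10 uM to 100 uM.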

Compound 4, half-maximal toxic concentration: 164 uM
Compound 4: middle estimate off by 5.5-fold (0.74 log units), on the low side; the measured number lies above the stated range.
By their numbers in this assay, from the lowest: compounds 2 and 3 (each within the scatter of the next); then compound 4; then compound 1.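

In this assay, for the compounds shown here, placing 3-hydroxypyridin-2-yl instead of 3-hydroxypropyl on the amide-type nitrogen gives a 3.6-fold higher number from compound 3 to compound 4 (0.55 log units; beyond the scatter), the first single-place step and the first read at this position. At this position, then, swapping the hydroxylated chain for this aromatic ring does not lower the number; it raises it, though the step is modest. Nothing measured here accounts for the step.

Still open, going by these compounds, is which part of the entering group goes with the step: a plain phenyl or a pyridin-2-yl without the hydroxyl on the same nitrogen would separate the ring nitrogen from the hydroxyl. Also open, on these data alone, is whether an amine or a carboxylic acid on that ring would move the number further.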